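Swapping the Aryl Group on the Saturated Ring Carbon

The source may hold more compounds than are shown below. What is called first, only, known or untested is meant among the compounds shown, and "the series" means these compounds.

Compound 1, `O=c1oc2ccccc2cc1C1=NN(c2ccccc2)[C@@H](c2ccc(Cl)cc2)C1`: 39.1%
Compound 2, `O=c1oc2ccccc2cc1C1=NN(c2ccccc2)[C@@H](c2ccc(Cl)cc2Cl)C1`: 45.4%

Going by the values given here, in a functional assay on the whole organism (strain albino) for inhibition, with Rattus norvegicus as the target, read by paw edema, at a dose of 200 mg/kg by the oral route (a lower number here means less inhibition, a higher number more inhibition at the dose given (going by the name of the read-out)), compound 2 gives 45.4%, the highest of the two numbers measured so far, though its only neighbour sits close by: the step of a number 6.3 percentage points higher from compound 1 to compound 2 (within the scatter) is within the scatter, so no order between the two can be claimed. That step, chloro in place of hydrogen on an aromatic carbon, is the only measured one, and it does not touch the change now at hand.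

Compound 3, `COc1cccc([C@H]2CC(c3cc4ccccc4oc3=O)=NN2c2ccccc2)c1`, differs from compound 2 in one place: 3-methoxyphenyl in place of 2,4-dichlorophenyl on a saturated ring carbon. Among the compounds with values here, no measured pair covers an exchange of this kind, so the expectation rests on compound 2 alone and is held loosely. The step of a number 3.4 percentage points lower from compound 2 to compound 3 (within the scatter) is expected to stay inside the scatter, with a wide margin either way. The estimate for compound 3 is therefore 42%, within a range from 25% to 58%.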

Compound 3, a percentage reported as inhibition, in the whole organism at one dose (the size of the read-out at that dose, not a potency): 20.9%
Beside the measured number, compound 3's estimate is 21.1 percentage points above it; the measured number lies below the stated range.
By their numbers in this assay, from the lowest: compound 3; then compounds 1 and 2 (each within the scatter of the next).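

The two steps show that this saturated ring carbon is not indifferent to its aryl group in this assay: 3-methoxyphenyl in place of 2,4-dichlorophenyl gives a number 24.5 percentage points lower from compound 2 to compound 3 (beyond the scatter), and 3-methoxyphenyl in place of 4-chlorophenyl gives a number 18.2 percentage points lower from compound 1 to compound 3 (beyond the scatter). Going by these compounds alone, the one earlier step on this aryl group stayed within the scatter, so these are the first changes here to exceed it. Among these three compounds, both chlorine-bearing aryl groups stand above the 3-methoxyphenyl group, and no compound goes against this. Nothing at hand explains the lower number.

The compounds shown leave open whether the lower number follows the loss of chlorine or the arrival of the methoxy group, as each exchange does both at once; a plain phenyl group on this carbon would help separate the two. On these data alone, how an aryl group carrying an amine or a carboxylic acid would read also remains open.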